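Two bicyclic triazole oxadiazoles and a benzyl variant awaiting measurement

A few compounds are considered here, and "the series" means these few. Any claim that something is new, unique, unknown or untested is made for them only; others in the source may bear on it.

Compound 1: `CN1CCC(n2nnc3c2CCC(c2nc(-c4ccc(F)cc4)no2)C3)CC1`, 3980 nM
Compound 2: `CC(C)Cc1noc(C2CCc3c(nnn3C(C)(C)C)C2)n1`, 1000 nM

In a functional assay on U2OS cells for positive allosteric modulation of metabotropic glutamate receptor 5 (Homo sapiens), read by calcium flux, in the presence of a further agent that is not named here (a lower number here means that less compound is needed, a higher number that more compound is needed for the effect), compound 2 gives the lower of the two numbers, and its gap to compound 1 lies beyond the usual scatter. Compound 3, `CC(C)(C)n1nnc2c1CCC(c1nc(Cc3ccc(F)cc3)no1)C2`, differs from compound 2 by 4-fluorophenyl in place of isopropyl on a saturated chain carbon bound to an aromatic carbon. Among the measured compounds shown here, no measured pair shows this change directly, so the step is expected to be small, a modest decrease at most, within or near the scatter, as a 1.3-fold lower number from compound 2 to compound 3 (0.10 log units; within the scatter). For compound 3 the estimate in this assay is 800 nM, with a range from 250 nM to 2500 nM.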

Compound 3, half-maximal effective concentration: 20 nM
Estimate against measurement, compound 3: 40-fold (1.60 log units) above, outside the stated range (below it).
By their numbers in this assay, from the lowest: compound 3; then compound 2; then compound 1.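

Putting 4-fluorophenyl in place of isopropyl on a saturated chain carbon bound to an aromatic carbon gives a 50-fold lower number from compound 2 to compound 3 (1.70 log units; beyond the scatter) in this assay. The earlier compounds shown here differ in more than one place and could not show that this position alone can move the number so far. Nothing given here accounts for the size of this step. The compounds shown leave open what the fluorine contributes, as a plain benzyl does not stand among them. Also open, from the compounds shown here alone, is how a longer chain, such as 2-phenylethyl, would read here.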